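The source may hold more compounds than are shown below. What is called first, only, known or untested is meant among the compounds shown, and "the series" means these compounds.

Measured so far:
compound 1 `O=C(c1ccc2c(c1)CC(c1nc3ccc(-c4cn[nH]c4)cc3c(=O)[nH]1)CO2)C1CC1`, 18 nM
compound 2 `O=c1[nH]c(C2CCc3ccccc3O2)nc2ccc(-c3cn[nH]c3)cc12`, 2 nM

Both compounds were tested in an assay on isolated protein for inhibition of Rho-associated protein kinase 2 (Homo sapiens), read by HTRF; on this read-out lower numbers stand for stronger inhibition and higher numbers for weaker inhibition. Compound 1 is the weaker of the two: in this assay compound 1 gives 18 nM, while compound 2 gives 2 nM, and that gap lies beyond the usual scatter of repeated measurements. Going by the values given here, no single-change step between the two has been worked out, so their values are taken as they stand.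

Compound 3 `COCCNC(=O)c1ccc2c(c1)CC(c1nc3ccc(-c4cn[nH]c4)cc3c(=O)[nH]1)CO2` has not yet been measured. It differs from compound 1 in one place: (2-methoxyethyl)amino in place of cyclopropyl on a carbonyl carbon. Among the compounds with values here, no measured pair shows what this kind of change does here, so the expectation rests on compound 1 alone. The step from compound 1 to compound 3 is expected to be small, at most a modest shift towards a lower number, a 1.8-fold lower number from compound 1 to compound 3 (0.26 log units; within the scatter), and quite possibly nothing beyond the scatter. Compound 3 is therefore estimated at 10 nM, with a range from 3 nM to 40 nM.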

Compound 3, half-maximal inhibitory concentration: < 1 nM
Compound 3: only a limit was reported; the forecaster's own chance of this, stated with the estimate: 2%; middle value at least 10-fold (1.00 log units) away from the limit.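

In this assay compound 3 gives < 1 nM, which is a limit of the assay and not a number. Going by these compounds alone, putting (2-methoxyethyl)amino in place of cyclopropyl on a carbonyl carbon gives an at least 18-fold lower number from compound 1 to compound 3 (1.25 log units; beyond the scatter), the first sign that the group on this carbonyl carbon can move the read-out far beyond the scatter. The full size of that step stays unknown, since the value of compound 3 sits at a limit: the limit of < 1 nM in this assay, at which 1 of the 3 values shown sits.

This one change removes a carbon ring and brings in an open chain with a hydrogen-bond donor and a hydrogen-bond acceptor, so the compounds shown cannot tell which of these differences matters. As far as these compounds go, how a plain ethylamino group, lacking the ether oxygen, would read on the same carbonyl carbon stays open.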